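Chloro to trifluoromethyl, compound 2 to compound 3

The compounds below may be only part of what the source reports. "The series", "measured", "known", "first", "only" and "open" are said of these compounds alone.

In an ADME assay on microsomes from liver (Rattus norvegicus) for metabolic stability (on this read-out lower numbers stand for a shorter-lived compound and higher numbers for a longer-lived compound), compound 1 (`N#Cc1ccc(-c2nc(NCCNc3ccc([N+](=O)[O-])c(N)n3)ncc2-c2ncc[nH]2)cc1`) is reported as > 0.5 h, which is a limit and not a number. Compound 2 (`Nc1nc(NCCNc2ncc(-c3ncc[nH]3)c(-c3ccc(Cl)cc3)n2)ccc1[N+](=O)[O-]`) is reported as > 0.5 h, again a limit and not a number. Within the data shown here, the series so far therefore rests on (the limit of > 0.5 h in this assay, at which 2 of the 2 values shown sit), and compound 2 has no exact position in this assay.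

Compound 3 (`Nc1nc(NCCNc2ncc(-c3ncc[nH]3)c(-c3ccc(C(F)(F)F)cc3)n2)ccc1[N+](=O)[O-]`) carries trifluoromethyl in place of chloro on an aromatic carbon. Among the measured compounds shown here, the only measured step that bears on this change is a step that the two limits leave unreadable from compound 1 to compound 2, with chloro in place of cyano on an aromatic carbon, and it offers no size to carry over. No step beyond the scatter is expected in either direction, and the expected step is a step that the limit leaves unreadable from compound 2 to compound 3. Compound 3 is estimated at 0.8 h, with an expected range of 0.4 h to 2 h.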

Compound 3, half-life: > 0.5 h
Compound 3: a limit, no number (the forecaster's own chance of this, stated with the estimate: 75%); the middle value lies beyond the limit too.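

No step can be read among compound 1, compound 2 and compound 3, because all three values are limits and not numbers: the limit of > 0.5 h in this assay, at which 3 of the 3 values shown sit.

Still open, on these data alone, is how far each half-life lies past that limit, and whether cyano, chloro and trifluoromethyl differ at all on this read-out.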